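The source may report more compounds than this note shows. Statements on the series, on what has been measured and on what is new or still open speak of the compounds shown alone.

In a functional assay on KB cells (Homo sapiens) for antiproliferative activity, read by colorimetric assay and MTT assay (a lower number here means a stronger inhibitor, a higher number a weaker inhibitor), compound 1 (`O=[N+]([O-])c1ccc(S(=O)(=O)Nc2cccc3cc[nH]c23)cc1`) gives 15 ug/mL and compound 2 (`N#Cc1ccc(S(=O)(=O)Nc2ccc(Cl)c3c(Cl)c[nH]c23)cc1`) gives 13 ug/mL while compound 3 (`Nc1ccc(S(=O)(=O)Nc2ccc(Cl)c3c(Cl)c[nH]c23)cc1`) gives 14 ug/mL so compound 3 stands level with both others, within the scatter. Compound 4 (`Nc1ccc(S(=O)(=O)Nc2ccc(-c3ccccc3)c3c(Cl)c[nH]c23)cc1`) has phenyl in place of chloro on an aromatic carbon. For the measured compounds named here, the only measured step (a 1.1-fold higher number from compound 2 to compound 3 (0.03 log units; within the scatter)) lies within the scatter, yet it swaps a different group, so no measurement speaks directly to replacing this chloro. No step beyond the scatter is therefore expected, though this expectation is loose. The expected step in this assay is small (a 1.2-fold lower number from compound 3 to compound 4 (0.07 log units; within the scatter)). Compound 4 is estimated at 12 ug/mL within an expected range (4 ug/mL to 35 ug/mL).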

Compound 4, half-maximal inhibitory concentration: 15 ug/mL
Compound 4: middle estimate off by 1.3-fold (0.10 log units), on the low side; the measured number falls inside the stated range.
By their numbers in this assay, from the lowest: compounds 2, 3, 1 and 4 (each within the scatter of the next).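

In this assay, phenyl in place of chloro gives a small step (a 1.1-fold higher number from compound 3 to compound 4 (0.03 log units; within the scatter)). This is the first step shown at this aromatic carbon, para to a large group, and it shows that a whole aromatic ring can replace a single chlorine without a change beyond the scatter. Nothing measured here gives a reason for this result.

Going by these compounds, it remains open whether a carboxylic acid or a methoxy group on this carbon would leave the number level as well. A longer chain, such as butyl, is equally untested by these compounds.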